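Swapping Cyclopropyl for Allyl in Two Amide Pairs

The source may report more compounds than this note shows. Statements on the series, on what has been measured and on what is new or still open speak of the compounds shown alone.

Four amides built on two closely related cores make up this set. Compound 1 `C/C(C(=O)NC1CC1)=C(\C)c1ccc(C)cc1` and compound 2 `C=CCNC(=O)/C(C)=C(/C)c1ccc(C)cc1` share one core; compound 3 `C/C(C(=O)NC1CC1)=C(/C)c1ccc(Cl)cc1` and compound 4 `C=CCNC(=O)/C(C)=C(\C)c1ccc(Cl)cc1` share the other. The difference between the two cores is not broken down here. Within each pair the amide nitrogen carries either a cyclopropyl or an allyl group.

In a toxicity assay on the whole organism (strain Icem-CET (SPF Caw)) for cytotoxicity, with Mus musculus as the target (a lower number here means that less compound is needed, a higher number that more compound is needed for the effect), compound 1 gives 280 mg/kg, and compound 2 gives 280 mg/kg. The change between them, (allyl in place of cyclopropyl on an amide-type nitrogen), made a step of no change at the digits printed from compound 1 to compound 2 (within the scatter). Compound 3 gives 350 mg/kg in this assay; its value and those of compound 1 and compound 2 lie within the usual scatter of one another, so no ordering among the three can be read from them.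

Compound 4 is not yet measured. It differs from compound 3 by allyl in place of cyclopropyl on an amide-type nitrogen, the same change, at the same place, as that seen in the first pair. Because the earlier change gave no change at the digits printed from compound 1 to compound 2 (within the scatter), compound 4 is expected to follow suit, with an estimated step of no change at the digits printed from compound 3 to compound 4 (within the scatter). The estimate for compound 4 in this assay is 350 mg/kg, most likely between 230 mg/kg and 530 mg/kg.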

Compound 4, dose for half-maximal effect: 70 mg/kg
Beside the measured number, compound 4's estimate is 5.0-fold (0.70 log units) above it; measured number outside the range, below it.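

In this assay, the allyl-for-cyclopropyl swap on the amide nitrogen gives a 5.0-fold lower number from compound 3 to compound 4 (0.70 log units; beyond the scatter), so the swap cannot simply be carried from one core to the other: the same change on two cores in this assay, no change at the digits printed (within the scatter) from compound 1 to compound 2 and a 5.0-fold lower number (0.70 log units; beyond the scatter) from compound 3 to compound 4, 5.0-fold (0.70 log units) apart, beyond the scatter of two such steps

Since a lower number here means that less compound is needed for the effect, the allyl amide needs the smaller dose on the core of compound 3, whereas on the core of compound 1 the same swap leaves the number unchanged. Going by these compounds alone, with only one pair on each core, this shows that the core can decide the outcome of the swap, but it does not show which feature of the cores is responsible, nor does it give a rule for any further core.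

As far as these compounds go, it remains open whether a propyl or cyclobutyl group on the amide nitrogen would behave like the allyl group in compound 4 on this core. From the compounds shown here alone, it is also open whether a third core, such as one carrying a methoxy group in place of the chlorine, would follow the first pair or the second.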